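The source may hold more compounds than are shown below. What is called first, only, known or untested is meant among the compounds shown, and "the series" means these compounds.

Three small phenolic compounds have been measured in a functional assay on HT-1080 cells (Homo sapiens) for cytotoxicity, read by MTT assay, with a stated time of 72 h (a higher number here means a weaker inhibitor, a lower number a stronger inhibitor), and a fourth awaits its result. Compound 1 `COc1ccc(CCC(=O)c2ccc(O)cc2)c(OC)c1` is the starting point. In this assay compound 1 gives > 100000 nM, which is a limit of the assay rather than a measured number. Two further compounds give numbers: compound 2 `COc1cc2c(cc1O)C[C@@H](Cc1ccc(O)cc1)CO2` gives 17500 nM in this assay, and compound 3 `Oc1ccc(C[C@H]2COc3cc(O)ccc3C2)cc1` gives 79600 nM. Among these, compound 1 stands apart as the one whose result is only a limit, as noted in the limit of > 100000 nM in this assay, at which 1 of the 3 values shown sits.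

Compound 4 `COc1ccc(CCC(=O)c2ccc(O)cc2)c(O)c1` differs from compound 1 in one place: hydrogen in place of methyl on an oxygen on an aromatic ring. Among the compounds with values here, no two measured compounds differ from each other in a single place, so no measured step sets a scale for a change of this kind. The step of a number no higher from compound 1 to compound 4 (the limit leaves the size open) is expected to stay within the usual scatter, since compound 1 already sits at the limit recorded in the limit of > 100000 nM in this assay, at which 1 of the 3 values shown sits. Compound 4 is therefore expected to give about 100000 nM, with a range from 40000 nM to 300000 nM, and a good chance that only a limit is reported again.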

Compound 4, half-maximal inhibitory concentration: > 100000 nM
Compound 4: only a limit was reported; the forecaster's own chance of this, stated with the estimate: 65%; the middle value sits exactly at the limit.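

Compound 1 and compound 4 both end at a limit rather than a number in this assay, so no step can be read between them: the limit of > 100000 nM in this assay, at which 2 of the 4 values shown sit. The compounds shown leave open what the change from methoxy to hydroxy does to the result in this assay.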